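Flipping the Double Bond Geometry in a Weak Cytotoxic Series

The source may hold more compounds than are shown below. What is called first, only, known or untested is meant among the compounds shown, and "the series" means these compounds.

Of the compounds shown here, three on a shared core have been measured in a functional assay on HL-60 cells (Homo sapiens) for cytotoxicity; a higher number here means a weaker inhibitor, a lower number a stronger inhibitor. Compound 1 `COc1ccc(/C=C\c2ccc3c(c2)C(C)(C)CCC3(C)C)cc1N` gives 25000 nM. Compound 3 `COc1ccc(/C=C/c2ccc3c(c2)C(C)(C)CCC3(C)C)cc1` gives 50000 nM. Compound 2 `C/C(=C/c1cccc(C(=O)O)c1)c1ccc2c(c1)C(C)(C)CCC2(C)C` gives 50000 nM, level with compound 3 at the digits shown and together with it the highest of the three numbers; its gap to compound 1 also lies within the scatter, so none of the three can be set apart from the others on these readings.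

Compound 4 `C/C(=C\c1cccc(C(=O)O)c1)c1ccc2c(c1)C(C)(C)CCC2(C)C` has not yet been measured. Relative to compound 2 it changes as follows: the two compounds have the same atoms and bonds and differ only in configuration as drawn: 1 of 1 stereo elements differ; a double bond is drawn Z in compound 2 and E in compound 4. Among the compounds with values here, no measured pair in this set differs in configuration alone, so there is no step from which the effect of this change can be read off. The expectation rests on the three measured compounds alone, which sit in a narrow band, and compound 4 is expected to remain in that band, with the step of a 1.4-fold lower number from compound 2 to compound 4 (0.15 log units; within the scatter) not expected to go beyond the scatter in either direction. Compound 4 is therefore estimated at 35000 nM, within a range from 12000 nM to 100000 nM.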

Compound 4, half-maximal inhibitory concentration: > 100000 nM
Compound 4 was reported as a limit; the forecaster's own chance of this, stated with the estimate: 15%; middle value at least 2.8-fold (0.45 log units) away from the limit.
By their numbers in this assay, from the lowest: compounds 1, 2 and 3 (each within the scatter of the next). At a limit, above all of these: compound 4.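

In this assay compound 4 is reported only as a limit (> 100000 nM). This pair gives the series its first step in which configuration alone changes (an at least 2.0-fold higher number from compound 2 to compound 4 (0.30 log units; that floor lies within the scatter)), but the floor of that step lies within the scatter, so the limit does not by itself set the two compounds apart. Any difference between them can rest only on the double bond, drawn Z in compound 2 and E in compound 4: the fact that compounds 2 and 4 differ only in the configuration as drawn.

The true size of the step cannot be read from this result: the limit of > 100000 nM in this assay, at which 1 of the 4 values shown sits. Also open, as far as these compounds go, is whether the same change of configuration would matter with a primary amide or a tetrazole in place of the carboxylic acid.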